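The source may hold more compounds than are shown below. What is called first, only, known or untested is meant among the compounds shown, and "the series" means these compounds.

The study follows a set of compounds in a functional assay on RCC4 cells (Homo sapiens) for inhibition, read by XTT assay, with a stated time of 4 days; on this read-out lower numbers stand for stronger inhibition and higher numbers for weaker inhibition. Among the measured compounds shown here, compound 1, `Cc1ccc(Nc2nc(-c3ccncc3)cs2)cc1`, gives 2510 nM in this assay and is the one compound reported with a single number, the other two entering with several entries each. Compound 2, `Cc1cccc(Nc2nc(-c3ccncc3-c3ccc(S(C)(=O)=O)cc3)cs2)c1`, gives 1600 nM; 1620 nM (2 entries) in this assay, its entries agreeing closely (the several entries of compound 2 in this assay, 1600 nM; 1620 nM (2 entries)). Compound 3, `Cc1cccc(Nc2nc(-c3ccncc3)c[nH]2)c1`, gives > 40000 nM; 40700 nM (2 entries) in this assay, its several entries agreeing with one another (the several entries of compound 3 in this assay, > 40000 nM; 40700 nM (2 entries)). Compound 1 and compound 2 lie within the usual scatter of each other, while compound 3 stands far weaker than either.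

Compound 4, `Cc1ccc(Nc2nc(-c3ccncc3)cs2)cc1O`, differs from compound 1 by hydroxy in place of hydrogen on an aromatic carbon. No measured pair of this kind is at hand among these compounds. The step from compound 1 to compound 4 in this assay is expected to be small, a 1.1-fold lower number from compound 1 to compound 4 (0.06 log units; within the scatter), in no clear direction beyond the scatter. Compound 4 is therefore estimated at 2200 nM in this assay, within a range from 700 nM to 7000 nM.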

Compound 4, half-maximal inhibitory concentration: 12000 nM
Compound 4: middle estimate off by 5.5-fold (0.74 log units), on the low side; the whole stated range lies below it.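

In this assay, hydroxy in place of hydrogen gives a 4.8-fold higher number from compound 1 to compound 4 (0.68 log units; beyond the scatter), a real weakening rather than scatter. This is the first change in a single place among the compounds shown, and it shows that this aromatic carbon, ortho to a methyl group and meta to a large group, is not indifferent to the addition of one oxygen atom. The measurements shown hold nothing that tells why the number rises at this position.

Going by these compounds, it remains open whether the weakening is specific to hydroxy or would also follow from a methoxy group, a fluorine atom or an amine on the same carbon. On these data alone, it is also open whether hydroxy would have a similar effect on other carbons of this ring.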